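Working notes: chloro in place of hydrogen on compound 2

The source may hold more compounds than are shown below. What is called first, only, known or untested is meant among the compounds shown, and "the series" means these compounds.

compound 1 (`CCOc1cc(C)cc(S(=O)(=O)c2cccc(N)c2C#N)c1`) gives 9000 nM
compound 2 (`Cc1cccc(S(=O)(=O)c2cccc(N)c2C#N)c1`) gives 179000 nM
compound 3 (`N#Cc1c(N)cccc1S(=O)(=O)c1cccc(F)c1`) gives > 200000 nM (a limit of the assay, not a number)

In a functional assay on MT4 cells (Homo sapiens) for cytotoxicity (a higher number here means a weaker inhibitor, a lower number a stronger inhibitor), compound 2 (179000 nM) has the higher of the two actual numbers. The value of compound 3 (> 200000 nM) is a limit of the assay. Compound 4 (`Cc1cc(Cl)cc(S(=O)(=O)c2cccc(N)c2C#N)c1`) comes from compound 2 by one change (chloro in place of hydrogen on an aromatic carbon). Going by the values given here, the closest precedent is compound 1, which carries ethoxy where compound 2 has hydrogen (a 20-fold higher number from compound 1 to compound 2 (1.30 log units; beyond the scatter)). The fluoro change (an at least 1.1-fold higher number from compound 2 to compound 3 (0.04 log units; that floor lies within the scatter)) is a different kind of step and gives only a floor. Going by compound 1 (9000 nM), a lower number is expected for compound 4, though a smaller step than ethoxy gave. The step is estimated and expected to be a 3.6-fold lower number from compound 2 to compound 4 (0.55 log units; beyond the scatter). Compound 4 is estimated at 50000 nM (expected range 15000 nM to 170000 nM).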

Compound 4, half-maximal inhibitory concentration: > 200000 nM
Compound 4: a limit, no number; the forecaster's own chance of this, stated with the estimate: 15%; middle value at least 4.0-fold (0.60 log units) from the limit.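

In this assay compound 4 gives > 200000 nM, which is a limit of the assay and not a number, and it adds a second compound to that limit: the limit of > 200000 nM in this assay, at which 2 of the 4 values shown sit.

Chloro in place of hydrogen gives an at least 1.1-fold higher number from compound 2 to compound 4 (0.04 log units; that floor lies within the scatter), so this step is only a floor and shows no lowering of the number. Chloro in place of ethoxy gives an at least 22-fold higher number from compound 1 to compound 4 (1.34 log units; beyond the scatter), so among the groups shown at this position, only ethoxy brings a clearly lower number.

Going by these compounds, whether methoxy, a longer chain such as propoxy, or an amine at this position would also lower the number stays open. How far compound 4 lies past the limit cannot be read.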